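This account rests on a few compounds, and the source may have more. Where it says the series, first, only, none or still open, it means among the compounds named here.

Working notes on the series. Compound 1 `COc1cc(/C=C/C(=O)C2=C(/C=C/c3ccc(O)c(OC)c3)NC(=O)NC2c2ccc(O)cc2)ccc1O`, compound 2 `COc1cc(/C=C/C(=O)C2=C(/C=C/c3ccc(O)c(OC)c3)NC(=S)NC2c2ccccc2)ccc1O` and compound 3 `COc1cc(/C=C/C(=O)C2=C(/C=C/c3ccc(O)c(OC)c3)NC(=S)NC2c2ccc(N(C)C)cc2)ccc1O` share one core and differ only in the group on a saturated ring carbon. In a functional assay, with a stated time of 20 min, tested at 10 uM (a higher number here means a stronger effect of the compound at the concentration tested, a lower number a weaker effect), compound 1 gives 75%, compound 2 gives 26.5% and compound 3 gives 72%. Compound 3 stands second highest of the three numbers in this assay: its nearest neighbour is compound 1, within the scatter, and its furthest is compound 2, beyond the scatter. Going by the values given here, the only single-point step measured so far, a number 45.5 percentage points higher from compound 2 to compound 3 (beyond the scatter), bears directly on the next change. Compound 4 `COc1cc(/C=C/C(=O)C2=C(/C=C/c3ccc(O)c(OC)c3)NC(=S)NC2c2ccccc2Cl)ccc1O` differs from compound 3 by 2-chlorophenyl in place of 4-(dimethylamino)phenyl on a saturated ring carbon. Among the compounds with values here, this removes the group whose entry carried the large step between compound 2 and compound 3 and brings in a group with no measured counterpart here, so compound 2 is the closest reference. A downward step beyond the scatter in this assay is therefore expected, a number 37 percentage points lower from compound 3 to compound 4 (beyond the scatter), because a number 45.5 percentage points higher from compound 2 to compound 3 (beyond the scatter) is here partly reversed. Compound 4 is estimated at 35% with a range from 15% to 60%. Within the data shown here, the range is kept wide as the entering chlorine has no precedent in the set.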

Compound 4, a percentage reported as activity, at one concentration (the size of the read-out at that concentration, not a potency): 43.2%
The estimate for compound 4 lay 8.2 percentage points below the measured number, and the stated range covers the measured number.
By their numbers in this assay, from the lowest: compound 2; then compound 4; then compounds 3 and 1 (each within the scatter of the next).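

In this assay, the saturated ring carbon now shows a second gain over the plain phenyl, a number 16.7 percentage points higher from compound 2 to compound 4 (beyond the scatter), with chloro in place of hydrogen on an aromatic carbon, so the dimethylamino group is not the only substituent on this aromatic ring that raises the read-out. That gain does not reach the level set by 4-(dimethylamino)phenyl, as 2-chlorophenyl in its place gives a number 28.8 percentage points lower from compound 3 to compound 4 (beyond the scatter), although this change alters both the substituent and where it sits on the aromatic ring, and the two cannot be separated. No measurement available here explains either step.

Open, as far as these compounds go, is whether the difference follows the substituent or its place on the aromatic ring, which 4-chlorophenyl and 2-(dimethylamino)phenyl would separate. Also open, from the compounds shown here alone, is how a different kind of substituent on this aromatic ring, such as a carboxylic acid, would read in this assay.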